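The compounds below may be only part of what the source reports. "The series", "measured", "known", "first", "only" and "open" are said of these compounds alone.

Of the compounds shown here, three built on one shared core have been measured in a functional assay on CCRF-CEM cells (Homo sapiens) for antiproliferative activity, with a stated time of 72 h; a higher number here means a weaker inhibitor, a lower number a stronger inhibitor. Compound 3 `COc1ccccc1CNc1ncnc2c1ncn2[C@@H]1O[C@H](CO)[C@@H](O)[C@H]1O` gives 3200 nM, the lowest of the three numbers. Compound 1 `OC[C@H]1O[C@@H](n2cnc3c(NCc4ccccc4F)ncnc32)[C@H](O)[C@@H]1O` gives 4600 nM, and compound 2 `OC[C@H]1O[C@@H](n2cnc3c(NCc4ccccc4Cl)ncnc32)[C@H](O)[C@@H]1O` gives 14500 nM. The step of a 1.4-fold lower number from compound 1 to compound 3 (0.16 log units; within the scatter) lies within the scatter, whereas a 4.5-fold lower number from compound 2 to compound 3 (0.66 log units; beyond the scatter) and a 3.2-fold higher number from compound 1 to compound 2 (0.50 log units; beyond the scatter) lie beyond it. Compound 4 `OC[C@H]1O[C@@H](n2cnc3c(NCc4ccc(F)c(F)c4F)ncnc32)[C@H](O)[C@@H]1O` differs from compound 3 in one place: 2,3,4-trifluorophenyl in place of 2-methoxyphenyl on a saturated chain carbon bound to a nitrogen on an aromatic ring. Among the measured compounds shown here, the one measured step that bears on this is a 1.4-fold lower number from compound 1 to compound 3 (0.16 log units; within the scatter), where a single fluoro stands in for methoxy and the change is within the scatter; no measured compound carries three fluorines, so the added two are untested. Compound 4 is therefore expected to show a 1.6-fold higher number from compound 3 to compound 4 (0.19 log units; within the scatter), with wide uncertainty. In this assay compound 4 is estimated at 5000 nM, between 1500 nM and 16000 nM.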

Compound 4, half-maximal inhibitory concentration: 58200 nM
The estimate for compound 4 lay 12-fold (1.07 log units) below the measured number; the measured number lies above the stated range.
By their numbers in this assay, from the lowest: compounds 3 and 1 (each within the scatter of the next); then compound 2; then compound 4.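

In this assay, among the compounds shown here, the group on this saturated chain carbon matters more than the earlier compounds showed: 2,3,4-trifluorophenyl gives an 18-fold higher number from compound 3 to compound 4 (1.26 log units; beyond the scatter), a 13-fold higher number from compound 1 to compound 4 (1.10 log units; beyond the scatter) and a 4.0-fold higher number from compound 2 to compound 4 (0.60 log units; beyond the scatter). A single fluoro therefore proved a poor guide to three fluorines on the ring. Nothing in the data shown explains this rise.

Still open, as far as these compounds go, is whether a difluorophenyl group would give a number nearer that of compound 1 or that of compound 4. Also open, from the compounds shown here alone, is how an aminophenyl or carboxyphenyl group would compare at this position.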